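Pyrimidinyl Amide Replaces Anisidine: Expected Cytotoxicity

The source may hold more compounds than are shown below. What is called first, only, known or untested is meant among the compounds shown, and "the series" means these compounds.

Measured compounds:
compound 1, `Cc1cc(C)cc(NC(=O)COc2cc(C)nc3ccc(C)cc23)c1`: 15900 nM
compound 2, `COc1ccc2nc(C)cc(NCC(=O)Nc3cc(C)cc(C)c3)c2c1`: 6310 nM
compound 3, `COc1ccc2nc(C)cc(OCC(=O)Nc3cc(C)ccc3OC)c2c1`: > 100000 nM

Of the compounds shown here, three have been tested in a toxicity assay on HepG2 cells (Homo sapiens) for inhibition, read by CellTiter-Glo, with a stated time of 48 h; on this read-out higher numbers stand for weaker inhibition and lower numbers for stronger inhibition. Compound 1 gives 15900 nM, and compound 2 gives the lower number 6310 nM. Of compound 3 only a limit is known, not a number: in this assay compound 3 gives > 100000 nM. Among the three results, that of compound 3 is the limit of > 100000 nM in this assay, at which 1 of the 3 values shown sits. Compound 3 therefore stands at the weak end of what has been measured, with its true value unresolved.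

The next compound, compound 4, `COc1ccc2nc(C)cc(OCC(=O)Nc3ccncn3)c2c1`, keeps the core of compound 3 and changes one group: pyrimidin-4-yl in place of 2-methoxy-5-methylphenyl on an amide-type nitrogen. Among the compounds with values here, no measured pair shows this kind of change, so nothing measured tells how much it shifts the read-out.

Because compound 3 gives only > 100000 nM, compound 4 is expected to stay weak as well. The step of a number no higher from compound 3 to compound 4 (the limit leaves the size open) is expected to be none beyond the scatter, with a fair chance that only a limit is reported again. Compound 4 is estimated at 100000 nM, between 30000 nM and 300000 nM.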

Compound 4, half-maximal inhibitory concentration: > 100000 nM
Compound 4: only a limit was reported; the forecaster's own chance of this, stated with the estimate: 65%; the middle value sits exactly at the limit.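

In this assay, within the data shown here, compound 4, like compound 3, is reported only as a limit, so no step between the two can be read: the limit of > 100000 nM in this assay, at which 2 of the 4 values shown sit.

The compounds shown leave open whether pyrimidin-4-yl in place of 2-methoxy-5-methylphenyl on the amide-type nitrogen shifts the read-out at all.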